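Methoxy for Fluoro on a Weak Growth Inhibitor

The source may report more compounds than this note shows. Statements on the series, on what has been measured and on what is new or still open speak of the compounds shown alone.

Compound 1, `COc1cccc(OC)c1/C=C(\C(=O)c1ccc(Br)cc1)S(=O)(=O)c1ccc(Br)cc1`, gives 10000 nM in a functional assay on DU-145 cells (Homo sapiens) for inhibition, read by trypan blue exclusion, with a stated time of 96 h; on this read-out higher numbers stand for weaker inhibition of growth and lower numbers for stronger inhibition of growth.
Compound 2, `COc1ccc(/C=C(\C(=O)c2ccc(Br)cc2)S(=O)(=O)c2ccc(Br)cc2)c(F)c1`, gives 10000 nM in this assay.

Compound 2 stands level with compound 1 at the digits shown, and the one measured step, no change at the digits printed from compound 1 to compound 2 (within the scatter), records no change within the scatter even though it exchanged one substituted ring for another on the double-bonded chain carbon. The unmeasured compound 3, `COc1ccc(/C=C(\C(=O)c2ccc(Br)cc2)S(=O)(=O)c2ccc(Br)cc2)c(OC)c1`, differs from compound 2 in one place: methoxy in place of fluoro on an aromatic carbon. Within the data shown here, the single measured step bears on this only loosely, as it also altered the substituents of the six-membered aromatic ring of carbon only and left the growth inhibition unchanged. Among the measured compounds shown here, no measured pair speaks directly to methoxy in place of fluoro. On that basis the step of no change at the digits printed from compound 2 to compound 3 (within the scatter) is expected to be none beyond the scatter, the reading staying where compound 2 sits with 10000 nM. Compound 3 is therefore estimated to give 10000 nM in this assay, with a range from 3000 nM to 30000 nM.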

Compound 3, concentration for 50% growth inhibition: 8000 nM
Estimate against measurement, compound 3: 1.3-fold (0.10 log units) above, and the stated range covers the measured number.
By their numbers in this assay, from the lowest: compounds 3, 1 and 2 (each within the scatter of the next).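

In this assay, methoxy in place of fluoro on an aromatic carbon, at the place ortho to a large group and meta to a methoxy group, gives a 1.3-fold lower number from compound 2 to compound 3 (0.10 log units; within the scatter) and so leaves the reading within the scatter, even with one more heavy atom and one more hydrogen-bond acceptor in the entering group. The swap of 2,6-dimethoxyphenyl for 2,4-dimethoxyphenyl gives a 1.3-fold lower number from compound 1 to compound 3 (0.10 log units; within the scatter), so this second comparison, which the earlier pair could not offer, shows that the two dimethoxy arrangements also stay within the scatter of each other. Nothing available explains why these exchanges leave the reading so flat.

The substituents shown on this ring are only methoxy and fluoro, so it remains open whether an amine or a carboxylic acid at the same place would shift growth inhibition beyond the scatter. Also open, as far as these compounds go, is whether changing the bromo groups on the other two rings, for instance to chloro or to a longer chain such as propoxy, would move the reading where these ring exchanges did not.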